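A few compounds are considered here, and "the series" means these few. Any claim that something is new, unique, unknown or untested is made for them only; others in the source may bear on it.

Compound 1 `COc1cc(-n2ncnc2-c2ccc(Cl)cc2)cc(OC)c1OC` was tested in a functional assay on A549 cells (Homo sapiens) for antiproliferative activity, read by MTT assay, with a stated time of 72 h; on this read-out lower numbers stand for stronger inhibition and higher numbers for weaker inhibition. There compound 1 reads > 10000 nM, which is a limit of the assay and not a number. Compound 2 `COc1cc(-n2ncnc2-c2ccc(OC(F)(F)F)cc2)cc(OC)c1OC` reads > 10000 nM, also a limit. Together they stand at the limit of > 10000 nM in this assay, at which 2 of the 3 values shown sit, and between them lies a step that the two limits leave unreadable from compound 1 to compound 2. Going by the values given here, compound 3 `CCOc1ccc(-c2ncnn2-c2cc(OC)c(OC)c(OC)c2)cc1` gives 100 nM, the only true number so far.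

Two large steps lead to compound 3: an at least 100-fold lower number from compound 1 to compound 3 (2.00 log units; beyond the scatter) and an at least 100-fold lower number from compound 2 to compound 3 (2.00 log units; beyond the scatter). Compound 4 `COc1ccccc1-c1ncnn1-c1cc(OC)c(OC)c(OC)c1` differs from compound 1 by 2-methoxyphenyl in place of 4-chlorophenyl on an aromatic carbon. Among the compounds with values here, no measured step makes this exact change. The closest guide is the ethoxy of compound 3, with an at least 100-fold lower number from compound 1 to compound 3 (2.00 log units; beyond the scatter), showing that an oxygen-linked group can bring a large gain, while compound 2 goes against any such rule, with its trifluoromethoxy group still at the limit. A gain is therefore expected, but a smaller one than that seen for compound 3. The expected change is an at least 5.0-fold lower number from compound 1 to compound 4 (0.69 log units; beyond the scatter), toward a lower number. For compound 4 the estimate is 2000 nM, with an expected range from 200 nM to 10000 nM.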

Compound 4, half-maximal inhibitory concentration: > 10000 nM
Compound 4 ended at the assay's limit (the forecaster's own chance of this, stated with the estimate: 35%); middle value at least 5.0-fold (0.69 log units) from the limit.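

Compound 4 reads > 10000 nM, a limit of the assay and not a number. No step can be read between compound 1 and compound 4, as both stand at the same limit: the limit of > 10000 nM in this assay, at which 3 of the 4 values shown sit. The compounds shown leave open how far 2-methoxyphenyl and 4-chlorophenyl differ in this assay.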